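Working notes on compounds 1 to 4

This account rests on a few compounds, and the source may have more. Where it says the series, first, only, none or still open, it means among the compounds named here.

Measured so far:
compound 1 `CC1=CC[C@H](C(C)(C)NC(=S)N/N=C/c2ccccc2)CC1` — > 100000 nM in a functional assay on NCI/ADR-RES cells (Homo sapiens) for inhibition, read by sulforhodamine B assay, with a stated time of 48 h; a lower number here means a stronger inhibitor of growth, a higher number a weaker inhibitor of growth
compound 2 `COc1ccc(/C=N/NC(=S)NC(C)(C)[C@H]2CC=C(C)CC2)cc1` — 43800 nM in this assay
compound 3 `CC1=CC[C@H](C(C)(C)NC(=S)N/N=C(\C)c2ccccc2)CC1` — > 100000 nM in this assay

The value of compound 1 is a limit of this assay, not a number. The value of compound 3 is likewise a limit. Compound 2 gives a number, and the change from compound 1 to compound 2 is methoxy in place of hydrogen on an aromatic carbon, which made an at least 2.2-fold lower number from compound 1 to compound 2 (0.35 log units; beyond the scatter). The same kind of change separates compound 3 from compound 4 `COc1ccc(/C(C)=N/NC(=S)NC(C)(C)[C@H]2CC=C(C)CC2)cc1`, namely (methoxy in place of hydrogen on an aromatic carbon); the two place lines read the same. How the core of compound 3 differs from the core of compound 1 is not broken down here. Evidence bearing on the measured step is thin: the limit of > 100000 nM in this assay, at which 2 of the 3 values shown sit, so the size of the step from compound 1 to compound 2 is itself only a lower bound.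

For compound 4 a step in this assay of about an at least 1.6-fold lower number from compound 3 to compound 4 (0.22 log units; that floor lies within the scatter) is expected, resting on the step of an at least 2.2-fold lower number from compound 1 to compound 2 (0.35 log units; beyond the scatter). Compound 4 is estimated at 60000 nM, with a range from 20000 nM to 200000 nM, and the assay may again report only a limit.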

Compound 4, concentration for 50% growth inhibition: > 100000 nM
Compound 4 ended at the assay's limit; the forecaster's own chance of this, stated with the estimate: 45%; at least 1.6-fold (0.22 log units) between middle value and limit.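

In this assay compound 4 gives > 100000 nM, a limit and not a number. Compound 3 also sits at a limit, so the change from phenyl to 4-methoxyphenyl between these two compounds cannot be read as a step. The compounds shown leave open whether the gain seen with methoxy on the core of compound 1 carries over to the core of compound 3: the limit of > 100000 nM in this assay, at which 3 of the 4 values shown sit.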